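Swapping the 2-hydroxyphenyl amide ring: compound 3 to compound 4

This account rests on a few compounds, and the source may have more. Where it says the series, first, only, none or still open, it means among the compounds named here.

Three amides were measured in an assay for inhibition of HSP60/HSP10 (Homo sapiens), with a stated time of 60 min; on this read-out lower numbers stand for stronger inhibition and higher numbers for weaker inhibition. Compound 1 `O=C(Nc1ccc(Sc2nc3ccccc3s2)c(Cl)c1)c1ccccc1O` gives > 100000 nM, which is a limit of the assay rather than a number. Compound 2 `O=C(Nc1ccccc1)c1cc(Br)ccc1O` likewise gives > 100000 nM, again a limit. Compound 3 `O=C(Nc1ccc(Sc2nc3ccccc3s2)cc1)c1ccccc1O` gives > 100000 nM, also a limit. So compound 3 stands at the limit, as do the other two, and the only single-point step, a step that the two limits leave unreadable from compound 1 to compound 3, cannot be read because both ends sit at the limit of > 100000 nM in this assay, at which 3 of the 3 values shown sit. Compound 4 `COc1c(Br)cccc1C(=O)Nc1ccc(Sc2nc3ccccc3s2)cc1` differs from compound 3 by a group of 9 heavy atoms (7 carbon, 1 oxygen, 1 bromine; one six-membered aromatic ring of carbon only) in place of a group of 7 heavy atoms (6 carbon, 1 oxygen; one six-membered aromatic ring of carbon only), on a carbonyl carbon. Going by the values given here, no measured step bears on this change, so in this assay a step of a number no higher from compound 3 to compound 4 (the limit leaves the size open) is expected, most likely ending in another limit. Compound 4 is estimated at 100000 nM, within 30000 nM to 300000 nM.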

Compound 4, half-maximal inhibitory concentration: > 100000 nM
Compound 4 gave a limit, no number; the forecaster's own chance of this, stated with the estimate: 85%; the middle value lies on the limit itself.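

Compound 3 and compound 4 both stand at a limit rather than a number, so no step between them can be read: the limit of > 100000 nM in this assay, at which 4 of the 4 values shown sit.

The compounds shown leave open which structure, if any, would give a measurable number in this assay.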